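Aryl ketone ring substitution in a pyrazole chalcone series

The source may hold more compounds than are shown below. What is called first, only, known or untested is meant among the compounds shown, and "the series" means these compounds.

Measured compounds:
compound 1 `COc1ccc(C(=O)/C=C/c2cc(-c3cc(OC)c(OC)c(OC)c3)n[nH]2)cc1OC` gives 100%
compound 2 `COc1ccc(C(=O)/C=C/c2cc(-c3cc(OC)c(OC)c(OC)c3)n[nH]2)cc1` gives 101%
compound 3 `COc1cc(-c2cc(/C=C/C(=O)c3ccc(F)c(F)c3)[nH]n2)cc(OC)c1OC` gives 104%

All three numbers come from a functional assay on OVCAR-3 cells (Homo sapiens) for cytotoxicity, read by sulforhodamine B assay, with a stated time of 48 h, tested at 0.1 uM; on this read-out higher numbers stand for a weaker effect at the one concentration tested and lower numbers for a stronger effect. Compound 1 sits at a value whose steps to the other two are both within the scatter: a number 1 percentage points higher from compound 1 to compound 2 (within the scatter) and a number 4 percentage points higher from compound 1 to compound 3 (within the scatter). The remaining pair behaves the same way, a number 3 percentage points higher from compound 2 to compound 3 (within the scatter). At the one concentration tested, the three compounds are therefore indistinguishable in this assay.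

Compound 4 `COc1cc(C(=O)/C=C/c2cc(-c3cc(OC)c(OC)c(OC)c3)n[nH]2)cc(OC)c1OC` is not yet measured. It differs from compound 1 as follows: methoxy in place of hydrogen on an aromatic carbon. The change touches the same aromatic ring of the ketone part that is varied in the measured steps. The step of a number 1 percentage points higher from compound 1 to compound 2 (within the scatter) removes a methoxy from this ring, and the step of a number 4 percentage points higher from compound 1 to compound 3 (within the scatter) exchanges the whole ring for a 3,4-difluorophenyl; neither moves the number beyond the scatter. Adding a methoxy on this ring is therefore expected to give no step beyond the scatter in this assay, a number 1 percentage points higher from compound 1 to compound 4 (within the scatter). Compound 4 is estimated at 101%, with a range from 92% to 110%.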

Compound 4, a percentage reported as activity, at one concentration (the size of the read-out at that concentration, not a potency): 105%
For compound 4 the middle estimate is 4 percentage points below the measured one; measured number inside the range.
By their numbers in this assay, from the lowest: compounds 1, 2, 3 and 4 (each within the scatter of the next).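

In this assay, the aromatic carbon ortho to a methoxy group and meta to a large group now carries a methoxy in place of hydrogen, and the result is a number 5 percentage points higher from compound 1 to compound 4 (within the scatter). For the compounds shown here, the earlier steps only removed a group from this ring or exchanged the whole ring, so this is the first reading of an addition to it, and the added methoxy at this carbon leaves the number within the scatter. Nothing at hand bears on why this change makes so little difference.

As far as these compounds go, whether an amine, a hydroxy group or a carboxylic acid at this same carbon would give a step beyond the scatter remains open. The single tested concentration also leaves open how these compounds compare at any other concentration.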